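The compounds below may be only part of what the source reports. "The series", "measured", "known", "first", "only" and "open" are said of these compounds alone.

Compound 1 (`CCc1ccc(-c2nc3ccccn3c2Sc2ccccc2)cc1`) has no exact number in a functional assay on SK-MEL-28 cells (Homo sapiens) for inhibition, read by MTT assay, with a stated time of 48 h; a lower number here means a stronger inhibitor, a higher number a weaker inhibitor. Its > 100000 nM is a limit of the assay and not a number. That result is the limit of > 100000 nM in this assay, at which 1 of the 3 values shown sits.

Two relatives do give numbers in this assay: compound 2 (`N#Cc1ccc(-c2nc3ccccn3c2Sc2ccccc2)cc1`) gives 67500 nM, and compound 3 (`Clc1ccc2nc(-c3ccccc3)c(Sc3ccccc3)n2c1`) gives 76900 nM. These two values lie within the scatter of each other.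

Compound 4 (`c1ccc(Sc2c(-c3cccs3)nc3ccccn23)cc1`) has not yet been measured. It carries thiophen-2-yl in place of 4-ethylphenyl on an aromatic carbon, a change that can be counted as thiophen-2-yl in place of 4-ethylphenyl on an aromatic carbon.

Within the data shown here, only one measured step touches the same group. With cyano in place of ethyl on an aromatic carbon, the data show an at least 1.4-fold lower number from compound 1 to compound 2 (0.17 log units; that floor lies within the scatter). That step alters only the ethyl end, whereas compound 4 loses the whole 4-ethylphenyl, so it is a loose guide. Among the measured compounds shown here, no measured compound carries thiophen-2-yl.

Since compound 2 gives 67500 nM and compound 3 gives 76900 nM, a value in the same weak region is expected. For compound 4, another limit of the assay would be no surprise. The expected change is small and towards a lower number, estimated as an at least 1.4-fold lower number from compound 1 to compound 4 (0.15 log units; that floor lies within the scatter).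

For compound 4 the estimated value is 70000 nM, with an expected range from 30000 nM to 100000 nM.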

Compound 4, half-maximal inhibitory concentration: 85300 nM
Estimate against measurement, compound 4: 1.2-fold (0.09 log units) below, and the stated range covers the measured number.
By their numbers in this assay, from the lowest: compounds 2, 3 and 4 (each within the scatter of the next). At a limit, above all of these: compound 1.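

Compound 4 is the first compound shown in which the whole ring on this aromatic carbon, next to the ring nitrogen, is exchanged, rather than only the end of the 4-ethylphenyl group, and five-membered thiophen-2-yl takes the place of a six-membered aromatic ring of carbon only. In this assay, the exchange for the 4-cyanophenyl group gives a 1.3-fold higher number from compound 2 to compound 4 (0.10 log units; within the scatter), so this assay does not tell the two rings apart, and thiophen-2-yl, with its sulfur, gives no separation from that aryl group at this position. The comparison with the 4-ethylphenyl group yields only an at least 1.1-fold lower number from compound 1 to compound 4 (0.06 log units; that floor lies within the scatter), and it can go no further since compound 1 remains a limit of the assay and not a number: the limit of > 100000 nM in this assay, at which 1 of the 4 values shown sits.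

The compounds shown leave open whether an amine or a carboxylic acid on this aromatic carbon would give a number beyond the scatter of those seen here. From the compounds shown here alone, all of them also keep the phenylsulfanyl group, so what another group in its place would do in this assay remains open as well.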